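From compound 3 to compound 4: adding an isopropyl group

The compounds below may be only part of what the source reports. "The series", "measured", "known", "first", "only" and "open" are said of these compounds alone.

In a functional assay on HCT-116 cells (Homo sapiens) for cytotoxicity, read by MTT assay, with a stated time of 48 h (on this read-out lower numbers stand for stronger inhibition of growth and higher numbers for weaker inhibition of growth), compound 3 (`Clc1cc2ncn(C3CCCC3)c2cc1Cl`) gives 37000 nM and sits within the scatter of compound 2 (`Nc1ccccc1Cn1c(C(F)(F)F)nc2cc(Cl)c(Cl)cc21`), which gives 26100 nM in the same test. Compound 1 (`FC(F)(F)c1nc2cc(Cl)c(Cl)cc2n1Cc1ccccc1`), at 8600 nM in that test, lies lower than compound 3, beyond the scatter.

Compound 4 (`CC(C)c1nc2cc(Cl)c(Cl)cc2n1C1CCCC1`) differs from compound 3 by isopropyl in place of hydrogen on an aromatic carbon in one place: isopropyl in place of hydrogen on an aromatic carbon. Within the data shown here, the only measured step, a 3.0-fold higher number from compound 1 to compound 2 (0.48 log units; beyond the scatter), brings in an amino group rather than isopropyl and bears on this change only loosely. Among the measured compounds shown here, no measured step adds a group at this carbon. Compound 1 and compound 2 both hold a group there, but they differ from compound 3 in other places too, and only compound 1 lies beyond the scatter of it, so they give a weak lead.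

The estimated step is a 1.5-fold lower number from compound 3 to compound 4 (0.17 log units; within the scatter) and it is expected to be small, toward a lower number. Compound 4 is estimated at 25000 nM with 10000 nM to 60000 nM as the expected range.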

Compound 4, concentration for 50% growth inhibition: 9000 nM
For compound 4 the middle estimate is 2.8-fold (0.44 log units) above the measured one; measured number below the stated range.
By their numbers in this assay, from the lowest: compounds 1 and 4 (each within the scatter of the next); then compounds 2 and 3 (each within the scatter of the next).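

In this assay, among these compounds, isopropyl in place of hydrogen on an aromatic carbon between two ring nitrogen atoms gives the first measured step at this carbon (a 4.1-fold lower number from compound 3 to compound 4 (0.61 log units; beyond the scatter)). With the cyclopentyl group held in place, this shows that a change at this carbon alone can move the number beyond the scatter, toward stronger inhibition of growth. Nothing measured here bears on the cause of this step.

The compounds shown leave open whether this step belongs to isopropyl in particular or would follow from other groups at this carbon. Going by these compounds, a methyl group, a longer chain such as butyl or an amine at this carbon would be needed to tell, and whether the step holds with other groups in place of the cyclopentyl group also remains open.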